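The source may report more compounds than this note shows. Statements on the series, on what has been measured and on what is new or still open speak of the compounds shown alone.

In a functional assay on MCF7 cells (Homo sapiens) for cytotoxicity, read by MTT assay, with a stated time of 24 h (a higher number here means a weaker inhibitor, a lower number a stronger inhibitor), compound 1 (`COc1ccc(/C=C(\C#N)C(=O)N/N=C(\C)c2c(O)c3ccc(O)cc3oc2=O)cc1`) gives 8940 nM and compound 2 (`COc1cc(/C=C(\C#N)C(=O)N/N=C(\C)c2c(O)c3ccc(O)cc3oc2=O)cc(OC)c1OC`) gives 11300 nM, two values within the usual scatter of each other. Compound 3 (`C/C(=N\NC(=O)/C(C#N)=C/c1ccc([N+](=O)[O-])cc1)c1c(O)c2ccc(O)cc2oc1=O`) has not yet been measured. It differs from compound 1 in one place, with nitro in place of methoxy on an aromatic carbon, para to a large group: nitro in place of methoxy on an aromatic carbon. Among the compounds with values here, no measured step covers this change, so the estimate rests only on these two close values. In this assay the expected step is a 1.1-fold lower number from compound 1 to compound 3 (0.05 log units; within the scatter), which would be none beyond the scatter. For compound 3 the estimated value is 8000 nM, within a range of 3000 nM to 20000 nM.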

Compound 3, half-maximal inhibitory concentration: 8200 nM
Beside the measured number, compound 3's estimate is 1.0-fold (0.01 log units) below it; the range from low to high includes it.
By their numbers in this assay, from the lowest: compounds 3, 1 and 2 (each within the scatter of the next).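

In this assay, within the data shown here, nitro in place of methoxy on an aromatic carbon, para to a large group, gives a first step at this position (a 1.1-fold lower number from compound 1 to compound 3 (0.04 log units; within the scatter)). The 4-methoxyphenyl and 4-nitrophenyl forms therefore cannot be told apart in this assay, although the two groups differ in their atoms and hydrogen-bond acceptor counts. No measurement on hand explains this result.

Going by these compounds, it remains open whether an amine or a carboxylic acid at this position would also stay within the scatter of compound 1.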